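Methoxy for Fluoro Within a Cytotoxicity Ceiling

The source may hold more compounds than are shown below. What is called first, only, known or untested is meant among the compounds shown, and "the series" means these compounds.

Three compounds of one series have been run in an ADME assay on MT4 cells (Homo sapiens) for cytotoxicity, read by MTT assay; on this read-out higher numbers stand for lower toxicity in this test and lower numbers for higher toxicity in this test. Compound 1 `CCc1c(Cc2c(Cl)cccc2Cl)nc(SCC(=O)c2ccc(F)cc2)[nH]c1=O` carries a fluoro group on the aromatic ring bound to the carbonyl, and in this assay compound 1 gives > 55000 nM, which is a limit of the test and not a number. Compound 2 `CCc1c(Cc2c(Cl)cccc2Cl)nc(SCC(=O)c2ccc(OC)cc2)[nH]c1=O` is made from it by methoxy in place of fluoro on an aromatic carbon; in this assay compound 2 gives > 54000 nM, again a limit. The step that the two limits leave unreadable from compound 1 to compound 2 therefore cannot be sized, because the limit of > 55000 nM in this assay, at which 1 of the 3 values shown sits, and the limit of > 54000 nM in this assay, at which 1 of the 3 values shown sits, both mark limits rather than numbers.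

Compound 3 `Cc1c(Cc2c(F)cccc2Cl)nc(SCC(=O)c2ccc(F)cc2)[nH]c1=O` belongs to a different core; how its core differs from the core of compound 1 is not broken down here. In this assay compound 3 gives > 59000 nM, and the limit of > 59000 nM in this assay, at which 1 of the 3 values shown sits, shows this too is a limit.

Compound 4 `COc1ccc(C(=O)CSc2nc(Cc3c(F)cccc3Cl)c(C)c(=O)[nH]2)cc1` has not yet been run. It differs from compound 3 by methoxy in place of fluoro on an aromatic carbon, the same change that turns compound 1 into compound 2. On that ground the step expected in this assay is a step that the limit leaves unreadable from compound 3 to compound 4, resting on the pair that already gave a step that the two limits leave unreadable from compound 1 to compound 2 and on the three limits recorded. Compound 4 is thus expected to give about 60000 nM, most likely reported as a limit, with a plausible range from 30000 nM to 200000 nM.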

Compound 4, half-maximal cytotoxic concentration: > 12000 nM
Compound 4 was reported as a limit (the forecaster's own chance of this, stated with the estimate: 85%); the middle value does not contradict the limit.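

In this assay compound 4 gives > 12000 nM, which is a limit of the test and not a number. Compound 3 also stands only at a limit, and no step can be read between compound 3 and compound 4. The compounds shown leave open whether going from 4-fluorophenyl to 4-methoxyphenyl changes the half-maximal cytotoxic concentration at all, and if it does, in which direction and by how much.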